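The source may report more compounds than this note shows. Statements on the series, on what has been measured and on what is new or still open speak of the compounds shown alone.

Compounds measured:
- Compound 1 `CCS(=O)(=O)Nc1ccc(C(C)C(=O)NCc2ccc(C(F)(F)F)nc2N2CCC(C)CC2)cc1F`: 4.4 nM
- Compound 2 `CC1CCN(c2nc(C(F)(F)F)ccc2CNC(=O)C(C)c2ccc(NS(=O)(=O)C(C)C)c(F)c2)CC1`: 8.7 nM
- Compound 3 `CC1CCN(c2nc(C(F)(F)F)ccc2CNC(=O)C(C)c2ccc(NS(N)(=O)=O)c(F)c2)CC1`: 2.7 nM

All three were tested in an assay on cells for antagonist activity at transient receptor potential cation channel subfamily V member 1 (Homo sapiens), read by FLIPR and calcium flux, with a stated time of 15 min; on this read-out higher numbers stand for weaker inhibition and lower numbers for stronger inhibition. Compound 3 gives the lowest of the three numbers in this assay, but its distance to compound 1 is small: a 1.6-fold lower number from compound 1 to compound 3 (0.21 log units; within the scatter). Against compound 2 the gap is larger: a 3.2-fold lower number from compound 2 to compound 3 (0.51 log units; beyond the scatter). Compound 4 `CC1CCN(c2nc(C(F)(F)F)ccc2CNC(=O)C(C)c2ccc(NS(=O)(=O)N(C)C)c(F)c2)CC1` has not been measured yet. It differs from compound 3 in one place: dimethylamino in place of amino on a sulfonyl sulfur.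

Going by the values given here, the steps that bear on this change are those in which the group on the sulfonyl sulfur grew or shrank. Read in reverse, they show that ethyl and isopropyl in place of amino gave higher numbers, the isopropyl step beyond the scatter. Adding two methyls on the sulfonamide nitrogen of compound 3 is a growth of the same kind, so a modestly higher number is expected for compound 4 in this assay, a 2.6-fold higher number from compound 3 to compound 4 (0.41 log units; beyond the scatter). Compound 4 is therefore estimated at 7 nM, with a range from 2.5 nM to 20 nM.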

Compound 4, inhibition constant: 42 nM
For compound 4 the middle estimate is 6.0-fold (0.78 log units) below the measured one; the whole stated range lies below it.
By their numbers in this assay, from the lowest: compounds 3, 1 and 2 (each within the scatter of the next, the first and the last beyond it); then compound 4.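

In this assay, amino, ethyl and isopropyl on the sulfonyl sulfur had stayed within a modest span, but dimethylamino falls clearly outside it: there is a 16-fold higher number from compound 3 to compound 4 (1.19 log units; beyond the scatter), alongside a 9.5-fold higher number from compound 1 to compound 4 (0.98 log units; beyond the scatter) and a 4.8-fold higher number from compound 2 to compound 4 (0.68 log units; beyond the scatter). This position therefore does not follow one smooth trend across these four groups, and the identity of the group matters here, not just the fact that amino is replaced: dimethylamino gives a higher number than both ethyl and isopropyl, each by a step beyond the scatter. No available evidence accounts for this jump.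

The compounds shown leave open whether methylamino on the same sulfur would stay with amino or move towards dimethylamino. They also leave open how a ring amine such as pyrrolidine or morpholine would read there.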